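A few compounds are considered here, and "the series" means these few. Any claim that something is new, unique, unknown or untested is made for them only; others in the source may bear on it.

Working notes on the series. In a functional assay on MKN-45 cells (Homo sapiens) for antiproliferative activity, read by MTT assay, with a stated time of 72 h (a lower number here means a stronger inhibitor, a higher number a weaker inhibitor), compound 1 (`CC(C)(O)COc1ccc2c(Oc3ccc(Nc4nccc5[nH]cc(-c6ccc(F)cc6)c(=O)c45)cc3F)ccnc2c1`) gives 2700 nM and compound 2 (`O=c1c(-c2ccc(F)cc2)c[nH]c2ccnc(Nc3ccc(Oc4ccnc5cc(O)ccc45)c(F)c3)c12`) gives 5000 nM. For the measured compounds named here, these two values lie within the scatter of each other, so compound 2 stands level with the only other compound measured so far.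

Compound 3 (`CC(O)COc1ccc2c(Oc3ccc(Nc4nccc5[nH]cc(-c6ccc(F)cc6)c(=O)c45)cc3F)ccnc2c1`) has not yet been measured in this assay. Its difference from compound 2 is 2-hydroxypropyl in place of hydrogen on an oxygen on an aromatic ring. In words, 2-hydroxypropyl stands in place of hydrogen on an oxygen on an aromatic ring.

Going by the values given here, one measured step bears on this change: a 1.9-fold higher number from compound 1 to compound 2 (0.27 log units; within the scatter). That step puts hydrogen in place of 2-hydroxy-2-methylpropyl on the same oxygen, and it stays within the scatter. Among the compounds with values here, with only this step as a guide, no shift beyond the scatter is expected in this assay for compound 3, in either direction. The data hold no other substituent at this oxygen to test that expectation.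

The expected change is a 1.5-fold lower number from compound 2 to compound 3 (0.18 log units; within the scatter), an estimated step that remains within the scatter. For compound 3 the estimated value is 3300 nM, with an expected range from 1400 nM to 7500 nM.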

Compound 3, half-maximal inhibitory concentration: 3100 nM
Compound 3: the middle estimate sits 1.1-fold (0.03 log units) above what was measured; the measured number falls inside the stated range.
By their numbers in this assay, from the lowest: compounds 1, 3 and 2 (each within the scatter of the next).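

In this assay, the step from hydroxy to 2-hydroxypropoxy on this oxygen is a 1.6-fold lower number from compound 2 to compound 3 (0.21 log units; within the scatter), so a second chain, 2-hydroxypropyl, also stays level with the free hydroxy compound, and hydrogen and both chains now lie within the scatter of one another. The earlier compounds shown here could not compare two chains at this oxygen; that comparison is now available as a 1.1-fold higher number from compound 1 to compound 3 (0.06 log units; within the scatter), which shows that the methyl separating 2-hydroxy-2-methylpropyl from 2-hydroxypropyl leaves the number within the scatter. No supporting measurement is available to account for this level reading.

Both chains shown carry a hydroxy group, so it remains open whether a plain methyl or propyl ether, an amine such as a dimethylaminopropyl chain, a carboxylic acid or a longer chain on this oxygen would produce a step beyond the scatter in this assay. The three compounds also share the rest of their structure, leaving open whether this level reading would hold if the 4-fluorophenyl group or the fluorine elsewhere on the core were replaced.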